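This account rests on a few compounds, and the source may have more. Where it says the series, first, only, none or still open, it means among the compounds named here.

Compound 1 `CC1=CC[C@@H]([C@@](C)(O)CCCC(C)(C)NC(=S)N/N=C\c2ccccc2)CC1` gives 130 nM
Compound 2 `COc1ccc(/C=N\NC(=S)NC(C)(C)CCC[C@](C)(O)[C@@H]2CC=C(C)CC2)cc1` gives 220 nM
Compound 3 `CC1=CC[C@@H]([C@@](C)(O)CCCC(C)(C)NC(=S)N/N=C\c2ccccc2[N+](=O)[O-])CC1` gives 190 nM

In a functional assay on K562 cells (Homo sapiens) for cytotoxicity, read by sulforhodamine B assay (a higher number here means a weaker inhibitor of growth, a lower number a stronger inhibitor of growth), compound 2 stands within the scatter of the other two compounds, as a 1.7-fold higher number from compound 1 to compound 2 (0.23 log units; within the scatter) and a 1.2-fold lower number from compound 2 to compound 3 (0.06 log units; within the scatter) show. Compound 4 `CC1=CC[C@@H]([C@@](C)(O)CCCC(C)(C)NC(=S)N/N=C(/C)c2ccccc2)CC1` is still unmeasured and differs from compound 2 as follows: a group of 9 heavy atoms (8 carbon, 1 nitrogen; one six-membered aromatic ring of carbon only) in place of a group of 10 heavy atoms (8 carbon, 1 nitrogen, 1 oxygen; one six-membered aromatic ring of carbon only), on an amide-type nitrogen. The two steps above bear on this change, together with a 1.5-fold higher number from compound 1 to compound 3 (0.16 log units; within the scatter). Each alters only a group on the aromatic ring, and none goes beyond the scatter. Within the data shown here, no measured step covers the rest of the change, so that part remains open. In this assay no step beyond the scatter is therefore expected, and the estimate amounts to a 1.3-fold lower number from compound 2 to compound 4 (0.11 log units; within the scatter). For compound 4 the expected value is 170 nM, with an estimated range of 70 nM to 400 nM.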

Compound 4, concentration for 50% growth inhibition: 10 nM
Beside the measured number, compound 4's estimate is 17-fold (1.23 log units) above it; the measured number lies below the stated range.
By their numbers in this assay, from the lowest: compound 4; then compounds 1, 3 and 2 (each within the scatter of the next).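

In this assay the group on the amide-type nitrogen can move the number well beyond the scatter, which the earlier changes on the aromatic ring did not do. The group of 9 heavy atoms gives a 13-fold lower number from compound 1 to compound 4 (1.11 log units; beyond the scatter) and a 22-fold lower number from compound 2 to compound 4 (1.34 log units; beyond the scatter), the latter in place of the group of 10 heavy atoms. No measurement at hand accounts for this shift.

Still open, as far as these compounds go, is whether an ethyl group or a longer chain in that place lowers the number further. From the compounds shown here alone, it is also open whether methoxy or nitro on the aromatic ring stays within the scatter when added to compound 4.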